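This account rests on a few compounds, and the source may have more. Where it says the series, first, only, none or still open, it means among the compounds named here.

Compound 1 `CC(C)(C)OC(=O)/C=C1/C(=O)Nc2ccccc21`: 89.5%
Compound 2 `COc1cccc2c1NC(=O)/C2=C/C(=O)OC(C)(C)C`: 87.6%

In a functional assay on HCT-116 cells (Homo sapiens) for inhibition, read by CCK-8 assay, with a stated time of 72 h, tested at 20 uM (a lower number here means less inhibition of growth, a higher number more inhibition of growth at the concentration tested), compound 1 gives 89.5%, and compound 2 gives 87.6%. Among the compounds with values here, the one measured step, a methoxy in place of hydrogen on an aromatic carbon, is a number 1.9 percentage points lower from compound 1 to compound 2 (within the scatter), so on these two numbers compound 1 and compound 2 stand together.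

Compound 3 `CC(C)(C)OC(=O)/C=C1/C(=O)Nc2ccc(OC(F)(F)F)cc21` differs from compound 1 by trifluoromethoxy in place of hydrogen on an aromatic carbon. Within the data shown here, the only step that bears on this change is the one from compound 1 to compound 2, which also added a substituent to the same ring and stayed within the scatter. For compound 3 a step of a number 3.5 percentage points lower from compound 1 to compound 3 (within the scatter) in this assay is therefore expected, nothing beyond the scatter. Compound 3 is estimated at 86%, within 74% to 95%.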

Compound 3, percent growth inhibition at one concentration: 87.7%
Compound 3: the middle estimate sits 1.7 percentage points below what was measured; the range from low to high includes it.
By their numbers in this assay, from the lowest: compounds 2, 3 and 1 (each within the scatter of the next).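

Trifluoromethoxy in place of hydrogen, on an aromatic carbon meta to a fused ring and para to a fused ring, gives in this assay a step of a number 1.8 percentage points lower from compound 1 to compound 3 (within the scatter) and no more. This carbon therefore carries a group of 5 heavy atoms, including 3 fluorine, with no change beyond the scatter at the one concentration tested. Nothing available explains this result. As far as these compounds go, whether an amine or a carboxylic acid on this same carbon would leave the number in place stays open. So does the effect of a longer alkoxy chain there.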